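A few compounds are considered here, and "the series" means these few. Any claim that something is new, unique, unknown or untested is made for them only; others in the source may bear on it.

Measured compounds in a functional assay on the whole organism (strain Sprague-Dawley) for inhibition, with Rattus norvegicus as the target, read by paw edema, with stated times of 30 min and 3 h, at a dose of 80 mg/kg by the oral route; on this read-out lower numbers stand for less inhibition and higher numbers for more inhibition at the one dose given (going by the name of the read-out):
compound 1 `Cc1nc2ccccc2c(=O)n1NS(=O)(=O)c1ccccc1` gives 47.8%;
compound 2 `Cc1ccc(S(=O)(=O)Nn2c(C)nc3ccccc3c2=O)cc1` gives 51.9%;
compound 3 `Cc1ccc(S(=O)(=O)Nn2c(CO[N+](=O)[O-])nc3ccccc3c2=O)cc1` gives 44.3%.

Compound 2 is not set apart from either neighbour: the step of a number 4.1 percentage points higher from compound 1 to compound 2 (within the scatter) and the step of a number 7.6 percentage points lower from compound 2 to compound 3 (within the scatter) both stay inside the usual scatter, so the three numbers read as one level.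

Compound 4 `CC(=O)Nc1ccc(S(=O)(=O)Nn2c(C)nc3ccccc3c2=O)cc1` differs from compound 2 by acetamido in place of methyl on an aromatic carbon. The step of a number 4.1 percentage points higher from compound 1 to compound 2 (within the scatter) is the one that touches the same aromatic carbon and it did not move the read-out beyond scatter; the step of a number 7.6 percentage points lower from compound 2 to compound 3 (within the scatter), elsewhere on the core, was likewise flat. Nothing here points to a shift, so the expected step of a number 2.9 percentage points lower from compound 2 to compound 4 (within the scatter) is none beyond the scatter. Compound 4 is estimated at 49%, with a range from 34% to 64%.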

Compound 4, a percentage reported as inhibition, in the whole organism at one dose (the size of the read-out at that dose, not a potency): 59.2%
For compound 4 the middle estimate is 10.2 percentage points below the measured one; measured number inside the range.
By their numbers in this assay, from the lowest: compounds 3, 1, 2 and 4 (each within the scatter of the next, the first and the last beyond it).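

At this aromatic carbon, para to a large group, acetamido gives the only step among the compounds shown that clears the scatter in this assay: a number 11.4 percentage points higher from compound 1 to compound 4 (beyond the scatter) for the exchange of hydrogen, a modest size. Methyl on the same carbon stayed within the scatter of hydrogen. Against methyl, however, acetamido gives a number 7.3 percentage points higher from compound 2 to compound 4 (within the scatter) and so cannot be ranked apart from it.

On these data alone, whether an amine or a carboxylic acid in place of acetamido would hold this level remains open. No supporting measurement bears on the reason for these steps.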